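Methoxy for Methyl: Expecting Compound 4 in the Cell Assay

This account rests on a few compounds, and the source may have more. Where it says the series, first, only, none or still open, it means among the compounds named here.

Measured compounds:
compound 1, `COc1ccc(C(=O)c2sc(Nc3ccc(F)cc3)nc2N)cc1`, gives > 10000 nM
compound 2, `Cc1ccc(Nc2nc(N)c(C(=O)c3ccccc3)s2)cc1`, gives 2800 nM
compound 3, `COc1ccc(Nc2nc(N)c(C(=O)c3cc(OC)c(OC)c(OC)c3)s2)cc1`, gives 1500 nM

In a functional assay on L1210 cells (Mus musculus) for antiproliferative activity, read by cell counting, with a stated time of 2 days (on this read-out lower numbers stand for stronger inhibition and higher numbers for weaker inhibition), compound 1 gives > 10000 nM, which is a limit of the assay and not a number (the limit of > 10000 nM in this assay, at which 1 of the 3 values shown sits). Compound 2 gives 2800 nM in this assay, and compound 3 gives 1500 nM; these two numbers sit within the scatter of each other, so no order between them can be read. Compound 4, `COc1ccc(Nc2nc(N)c(C(=O)c3ccccc3)s2)cc1`, is not yet measured. It differs from compound 2 in one place: methoxy in place of methyl on an aromatic carbon. For the measured compounds named here, compound 3 also carries methoxy on that ring but differs from compound 2 in further places as well, so it offers no clean single step to lean on. With only this to go by, compound 4 is expected to show a step of a 1.3-fold lower number from compound 2 to compound 4 (0.10 log units; within the scatter) from compound 2, small and within the scatter, in either direction. Compound 4 is therefore expected to give about 2200 nM in this assay, between 800 nM and 6000 nM.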

Compound 4, half-maximal inhibitory concentration: 850 nM
For compound 4 the middle estimate is 2.6-fold (0.41 log units) above the measured one; measured number inside the range.
By their numbers in this assay, from the lowest: compounds 4, 3 and 2 (each within the scatter of the next, the first and the last beyond it). At a limit, above all of these: compound 1.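

In this assay, the step of a 3.3-fold lower number from compound 2 to compound 4 (0.52 log units; beyond the scatter) is the only comparison among these compounds that changes a single place, and it lies beyond the scatter. For the compounds shown here, it shows that activity in this assay responds to the group on this aromatic carbon, para to a large group, when methoxy stands in place of methyl, something the earlier compounds, which offered no such pair, could not show. Nothing measured here bears on what lies behind this step.

From the compounds shown here alone, with only methyl and methoxy compared at this place, it remains open how an amine, a hydroxyl group, a chlorine atom or a longer chain such as ethoxy would fare there. The compounds shown also leave open whether the same change would give a similar step on a differently substituted benzoyl partner.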